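This account rests on a few compounds, and the source may have more. Where it says the series, first, only, none or still open, it means among the compounds named here.

Three compounds have been measured in a functional assay on HeLa cells (Homo sapiens) for inhibition; on this read-out higher numbers stand for weaker inhibition and lower numbers for stronger inhibition:

compound 1, `Oc1cccc(-c2cc(-c3cccc(F)c3)cc(-c3cccc(O)c3)n2)c1`, gives 1400 nM;
compound 2, `Oc1cccc(-c2cc(-c3ccc(F)cc3)cc(-c3cccc(O)c3)n2)c1`, gives 1280 nM;
compound 3, `Oc1cccc(-c2cc(-c3ccccc3C(F)(F)F)cc(-c3cccc(O)c3)n2)c1`, gives 15200 nM.

Compound 3 stands highest of the three, which on this read-out makes it the weakest inhibitor: compound 1 sits nearest to it and compound 2 furthest, and both gaps lie beyond the scatter. The unmeasured compound 4 is `Oc1cccc(-c2cc(-c3ccc(C(F)(F)F)cc3)cc(-c3cccc(O)c3)n2)c1`. It differs from compound 3 in one place: 4-(trifluoromethyl)phenyl in place of 2-(trifluoromethyl)phenyl on an aromatic carbon. Among the compounds with values here, two measured steps bear on this change: an 11-fold higher number from compound 1 to compound 3 (1.04 log units; beyond the scatter) and a 12-fold higher number from compound 2 to compound 3 (1.07 log units; beyond the scatter), both large. A third step, a 1.1-fold lower number from compound 1 to compound 2 (0.04 log units; within the scatter), shows that moving a single fluorine within the ring left the number essentially unchanged. Within the data shown here, no measured pair moves a trifluoromethyl group itself, so the size of the return is uncertain. Among the measured compounds shown here, compound 3, with its 2-(trifluoromethyl)phenyl group, is the only one with a high number, and compound 4 carries 4-(trifluoromethyl)phenyl much as compound 2 carries 4-fluorophenyl, so compound 4 is expected to move back toward the lower numbers, with a 6.1-fold lower number from compound 3 to compound 4 (0.78 log units; beyond the scatter) as the expected step. Compound 4 is therefore estimated at 2500 nM, within a range from 900 nM to 7000 nM.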

Compound 4, half-maximal inhibitory concentration: > 50000 nM
Compound 4 gave a limit, no number (the forecaster's own chance of this, stated with the estimate: 3%); middle value at least 20-fold (1.30 log units) away from the limit.
By their numbers in this assay, from the lowest: compounds 2 and 1 (each within the scatter of the next); then compound 3. At a limit, above all of these: compound 4.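

In this assay, compound 4 gave no number but a limit: the limit of > 50000 nM in this assay, at which 1 of the 4 values shown sits. Shifting the trifluoromethyl group, with 4-(trifluoromethyl)phenyl in place of 2-(trifluoromethyl)phenyl and the same atoms joined differently, gives an at least 3.2-fold higher number from compound 3 to compound 4 (0.51 log units; beyond the scatter), so the 2-(trifluoromethyl)phenyl group is not alone in giving a high number, and where this group sits on the phenyl ring clearly counts. Trifluoromethyl in place of fluoro gives an at least 39-fold higher number from compound 2 to compound 4 (1.59 log units; beyond the scatter), and 4-(trifluoromethyl)phenyl in place of 3-fluorophenyl gives an at least 35-fold higher number from compound 1 to compound 4 (1.55 log units; beyond the scatter), so at this position, opposite the ring nitrogen, the identity of the group on the phenyl ring can matter far more than the pair of compound 1 and compound 2, which lie within the scatter of each other, could show.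

Going by these compounds, with a limit in place of a number, the true size of these three steps stays unknown. Also open, on these data alone, is whether a smaller change at the same spot on the phenyl ring, such as a methyl group, a methoxy group or an amine in place of the trifluoromethyl, would sit with the lower numbers or the higher ones.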